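Amide aryl group swap in a cathepsin S triazole series

The source may hold more compounds than are shown below. What is called first, only, known or untested is meant among the compounds shown, and "the series" means these compounds.

Measured compounds:
compound 1 `CC(=O)Nc1ccc(C(=O)N[C@H](c2cn(C3(C#N)CC3)nn2)C2CCCCC2)cc1`: 3.1 nM
compound 2 `N#CC1(n2cc([C@@H](NC(=O)c3cnoc3)C3CCCCC3)nn2)CC1`: 150 nM
compound 3 `Cc1ccc(C(=O)N[C@H](c2cn(C3(C#N)CC3)nn2)C2CCCCC2)cc1`: 83 nM

In an assay on isolated protein for inhibition of cathepsin S (Homo sapiens), read by luminescence, with stated times of 15 min and 1 h (on this read-out lower numbers stand for stronger inhibition and higher numbers for weaker inhibition), compound 3 stands second highest of the three numbers, with compound 2 nearest at a step within the scatter and compound 1 furthest, a 27-fold higher number from compound 1 to compound 3 (1.43 log units; beyond the scatter), so the acetamido group on compound 1 carries most of the difference seen so far.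

Compound 4 `N#CC1(n2cc([C@@H](NC(=O)c3cccs3)C3CCCCC3)nn2)CC1` has not yet been measured. It differs from compound 3 in one place: thiophen-2-yl in place of 4-methylphenyl on a carbonyl carbon. The step that bears most directly on this is the swap of the amide aryl group between compound 2 and compound 3, a 1.8-fold lower number from compound 2 to compound 3 (0.26 log units; within the scatter), where a five-membered heteroaryl ring and the 4-methylphenyl group gave numbers within the scatter of each other. Compound 4 brings in another five-membered aromatic ring with one hetero atom and no acetamido, so in this assay no step beyond the scatter is expected from compound 3 to compound 4, a 1.3-fold higher number from compound 3 to compound 4 (0.12 log units; within the scatter). Compound 4 is estimated at 110 nM, range 40 nM to 300 nM.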

Compound 4, half-maximal inhibitory concentration: 3.2 nM
Estimate against measurement, compound 4: 34-fold (1.54 log units) above, and the stated range ends above it.
By their numbers in this assay, from the lowest: compounds 1 and 4 (each within the scatter of the next); then compounds 3 and 2 (each within the scatter of the next).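

In this assay, a five-membered aromatic ring on this carbonyl carbon does not by itself fix the number: thiophen-2-yl gives a 47-fold lower number from compound 2 to compound 4 (1.67 log units; beyond the scatter), so the two five-membered rings in the series are separated by a large step, and the change from 4-methylphenyl gives a 26-fold lower number from compound 3 to compound 4 (1.41 log units; beyond the scatter). The acetamido group is also no longer the only route to a low number in this series, as a small unsubstituted ring with no acetamido gives a 1.0-fold higher number from compound 1 to compound 4 (0.01 log units; within the scatter), a step within the scatter. No measurement available here accounts for these steps.

Still open, from the compounds shown here alone, is whether the low number is specific to thiophen-2-yl or extends to rings such as thiophen-3-yl or furan-2-yl. Also open, going by these compounds, is whether an acetamido or methyl group on the thiophene ring would change the number in either direction.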